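Difluoro for methoxy on the aryl ketone of compound 3

The source may hold more compounds than are shown below. What is called first, only, known or untested is meant among the compounds shown, and "the series" means these compounds.

In a functional assay on HCT-116 cells (Homo sapiens) for cytotoxicity, read by sulforhodamine B assay, with a stated time of 48 h, tested at 10 uM (a lower number here means a stronger effect, a higher number a weaker effect of the compound at the concentration tested), three compounds of one series have been measured. Compound 1 `COc1cc(-c2cc(/C=C/C(=O)c3ccc(N)cc3)[nH]n2)cc(OC)c1OC` gives -78%, compound 2 `COc1cc(-c2cc(/C=C/C(=O)c3ccc(Cl)c(Cl)c3)[nH]n2)cc(OC)c1OC` gives 16%, and compound 3 `COc1ccc(C(=O)/C=C/c2cc(-c3cc(OC)c(OC)c(OC)c3)n[nH]2)cc1` gives -22%. Compound 3 thus stands second highest of the three numbers, nearer to compound 2 and far from compound 1. Compound 4 `COc1cc(-c2cc(/C=C/C(=O)c3ccc(F)c(F)c3)[nH]n2)cc(OC)c1OC` is not yet measured; it differs from compound 3 in one place: 3,4-difluorophenyl in place of 4-methoxyphenyl on a carbonyl carbon. The step that bears most directly on this change sits on the same carbonyl carbon, a number 38 percentage points lower from compound 2 to compound 3 (beyond the scatter). The other halogen step, a number 94 percentage points higher from compound 1 to compound 2 (beyond the scatter), replaced an aminophenyl rather than a methoxyphenyl and is less comparable. A dihalogenated ring entering in place of the methoxy ring would therefore be expected to move the number upward, though fluorine is not chlorine and the size is uncertain. Compound 4 is expected to give 5%, between -30% and 35%. The step of a number 27 percentage points higher from compound 3 to compound 4 (beyond the scatter) is accordingly expected to lie beyond the scatter.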

Compound 4, a percentage reported as activity, at one concentration (the size of the read-out at that concentration, not a potency): 9%
Compound 4: middle estimate off by 4 percentage points, on the low side; measured number inside the range.
By their numbers in this assay, from the lowest: compound 1; then compound 3; then compounds 4 and 2 (each within the scatter of the next).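

In this assay, 3,4-difluorophenyl in place of 4-methoxyphenyl on the carbonyl carbon gives a number 31 percentage points higher from compound 3 to compound 4 (beyond the scatter) and so shows that the shift away from the methoxy ring also occurs with fluorine, not only with chlorine. The exchange of 3,4-dichlorophenyl for 3,4-difluorophenyl gives a number 7 percentage points lower from compound 2 to compound 4 (within the scatter) and thus separates neither halogen pair from the other at this position. The 4-aminophenyl ring stays apart from the difluorinated ring, with a number 87 percentage points higher from compound 1 to compound 4 (beyond the scatter) as the step between them, so among these four compounds the ring on the carbonyl carbon separates compound 1 and compound 3 from the two dihalogenated compounds.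

Nothing available here gives a reason for these differences. From the compounds shown here alone, it remains open whether a single fluorine, as in 4-fluorophenyl, or a 4-hydroxyphenyl ring would stay with the dihalogenated compounds or move towards compound 1.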